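Acetylation at the Amine Terminus of a Dioxygenase Inhibitor

The source may report more compounds than this note shows. Statements on the series, on what has been measured and on what is new or still open speak of the compounds shown alone.

compound 1 `O/N=C(\Nc1ccc(F)c(Br)c1)c1nonc1NCc1ccccc1`: 230 nM
compound 2 `NCCNc1nonc1/C(=N/O)Nc1ccc(F)c(Br)c1`: 290 nM

In an assay for inhibition of Indoleamine 2,3-dioxygenase 1 (Homo sapiens) (on this read-out higher numbers stand for weaker inhibition and lower numbers for stronger inhibition), compound 2 gives 290 nM. Among the two numbers shown, compound 2 sits alongside compound 1 at 230 nM, the gap being within the scatter. Compound 3 `CC(=O)NCCNc1nonc1/C(=N/O)Nc1ccc(F)c(Br)c1` differs from compound 2 by acetyl in place of hydrogen on an amine nitrogen. Within the data shown here, no measured step covers acetylation of this amine. Among the measured compounds shown here, the one step that touches the same chain end, a 1.3-fold higher number from compound 1 to compound 2 (0.10 log units; within the scatter), stayed within the scatter. The step to compound 3 is therefore expected to be small, a 1.2-fold higher number from compound 2 to compound 3 (0.08 log units; within the scatter). Compound 3 is estimated at 350 nM, with a range from 120 nM to 1000 nM.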

Compound 3, half-maximal inhibitory concentration: 210 nM
Estimate against measurement, compound 3: 1.7-fold (0.22 log units) above; low and high end bracket the measured number.
By their numbers in this assay, from the lowest: compounds 3, 1 and 2 (each within the scatter of the next).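

In this assay, acetyl in place of hydrogen on the amine nitrogen gives a 1.4-fold lower number from compound 2 to compound 3 (0.14 log units; within the scatter) and so, unlike the earlier comparison, this step tests the chain end itself: 2-aminoethyl and 2-acetamidoethyl cannot be told apart on this read-out. Acetamidomethyl in place of phenyl likewise gives a 1.1-fold lower number from compound 1 to compound 3 (0.04 log units; within the scatter) so all three compounds lie within the scatter of their neighbours, whether the chain ends in phenyl, an amine or an acetamide. No evidence at hand bears on this result.

On these data alone, whether a carboxylic acid or a longer chain at this position would also stay within the scatter remains open. So does whether any group here can move the number beyond the scatter at all.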